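Chain lengthening from compound 3 to compound 4

The compounds below may be only part of what the source reports. "The series", "measured", "known", "first", "only" and "open" are said of these compounds alone.

Compound 3 `CN(C)CCn1c(N)c(-c2nc3cc(Cl)ccc3[nH]2)c2nc(C#N)c(C#N)nc21` gives > 50000 nM in a functional assay on HL60/MX2 cells (Homo sapiens) for antiproliferative activity, read by MTT assay, with a stated time of 48 h (on this read-out lower numbers stand for stronger inhibition and higher numbers for weaker inhibition), and this is a limit of the assay and not a number. Compound 4 `CN(C)CCCn1c(N)c(-c2nc3cc(Cl)ccc3[nH]2)c2nc(C#N)c(C#N)nc21` is reached through ((dimethylamino)methyl in place of dimethylamino on a saturated chain carbon, two bonds along the chain from an aromatic nitrogen), which turns the 2-(dimethylamino)ethyl chain into 3-(dimethylamino)propyl. Among the measured compounds shown here, no measured step changes this chain on its own.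

The nearest evidence comes from two compounds that already carry 3-(dimethylamino)propyl. Compound 1 `CN(C)CCCn1c(N)c(-c2nc3ccccc3[nH]2)c2nc(C#N)c(C#N)nc21` gives 2390 nM and compound 2 `CN(C)CCCn1c(N)c(-c2nc3ccccc3o2)c2nc(C#N)c(C#N)nc21` gives 1310 nM in this assay. For the measured compounds named here, the only measured step, a 1.8-fold lower number from compound 1 to compound 2 (0.26 log units; within the scatter), leaves the chain untouched and lies within the scatter, so it suggests no large sensitivity to the group exchanged there. Compound 4 differs from compound 1 by a chloro group, whose contribution has not been measured separately, and this widens the range.

A lower number, meaning stronger inhibition, is therefore expected, an estimated at least 16-fold lower number from compound 3 to compound 4 (1.22 log units; beyond the scatter). Compound 4 is expected at about 3000 nM, with an estimated range of 700 nM to 15000 nM.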

Compound 4, half-maximal inhibitory concentration: 5310 nM
Compound 4: middle estimate off by 1.8-fold (0.25 log units), on the low side; the range from low to high includes it.
By their numbers in this assay, from the lowest: compounds 2 and 1 (each within the scatter of the next); then compound 4. At a limit, above all of these: compound 3.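

In this assay, going from 2-(dimethylamino)ethyl to 3-(dimethylamino)propyl with 5-chloro-1H-benzimidazol-2-yl held fixed gives an at least 9.4-fold lower number from compound 3 to compound 4 (0.97 log units; beyond the scatter), so chain length matters in this pair. Compound 3 stands at a limit of the assay and not a number, so this step gives only a bound: the limit of > 50000 nM in this assay, at which 1 of the 4 values shown sits. With the chain held at 3-(dimethylamino)propyl, chloro in place of hydrogen gives a 2.2-fold higher number from compound 1 to compound 4 (0.35 log units; beyond the scatter), and 5-chloro-1H-benzimidazol-2-yl in place of 1,3-benzoxazol-2-yl gives a 4.1-fold higher number from compound 2 to compound 4 (0.61 log units; beyond the scatter), both modest steps.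

As far as these compounds go, whether the chain step carries over to 1H-benzimidazol-2-yl or 1,3-benzoxazol-2-yl remains open. Also open, from the compounds shown here alone, are a longer chain such as 4-(dimethylamino)butyl and a cyclic amine such as morpholine in place of dimethylamino.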